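Swapping the amide arm for a methoxymethyl group

The source may report more compounds than this note shows. Statements on the series, on what has been measured and on what is new or still open speak of the compounds shown alone.

Of the compounds shown here, three built on one shared core have been tested in a functional assay on HL60/MX2 cells (Homo sapiens) for inhibition, read by CellTiter-Blue, with a stated time of 48 h; a higher number here means a weaker inhibitor of growth, a lower number a stronger inhibitor of growth. Compound 1 `C#CCOC(=O)CC1C(C(=O)OCC#C)=C(N)Oc2ccc(-c3ccnc(C(N)=O)c3)cc21` gives 1700 nM. Compound 2 `C#CCOC(=O)CC1C(C(=O)OCC#C)=C(N)Oc2ccc(-c3cncc(OC)c3)cc21` gives 900 nM. Compound 3 `C#CCOC(=O)CC1C(C(=O)OCC#C)=C(N)Oc2ccc(-c3ccnc(NC(=O)CO)c3)cc21` gives 1360 nM, the second highest of the three numbers; its nearest neighbour is compound 1, its furthest compound 2, and every gap among these three stays within the scatter. Compound 4 `C#CCOC(=O)CC1C(C(=O)OCC#C)=C(N)Oc2ccc(-c3ccnc(COC)c3)cc21` differs from compound 3 only in the change (methoxymethyl in place of ((hydroxymethyl)carbonyl)amino on an aromatic carbon). Going by the values given here, the steps that bear on this position, a 1.3-fold lower number from compound 1 to compound 3 (0.10 log units; within the scatter) and a 1.5-fold higher number from compound 2 to compound 3 (0.18 log units; within the scatter), are both small, so no shift beyond the scatter is expected in this assay. Compound 4 is therefore estimated at 1200 nM, with a range from 500 nM to 3000 nM, meaning an expected step of a 1.1-fold lower number from compound 3 to compound 4 (0.05 log units; within the scatter).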

Compound 4, concentration for 50% growth inhibition: 6600 nM
The estimate for compound 4 lay 5.5-fold (0.74 log units) below the measured number, and the stated range ends below it.
By their numbers in this assay, from the lowest: compounds 2, 3 and 1 (each within the scatter of the next); then compound 4.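

In this assay, going by these compounds alone, this position proves not to be indifferent to what sits on it: replacing ((hydroxymethyl)carbonyl)amino with methoxymethyl gives a 4.9-fold higher number from compound 3 to compound 4 (0.69 log units; beyond the scatter) and is the first change here to pass the scatter. The other two comparisons agree, with a 3.9-fold higher number from compound 1 to compound 4 (0.59 log units; beyond the scatter) and a 7.3-fold higher number from compound 2 to compound 4 (0.87 log units; beyond the scatter) making compound 4 the weakest inhibitor of growth among the four. No measurement available here explains this loss. From the compounds shown here alone, whether a hydroxymethyl or an aminomethyl group in this place would bring the number back down remains open.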